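Butoxy to 2,2,2-trifluoroethoxy on the shared core

The source may report more compounds than this note shows. Statements on the series, on what has been measured and on what is new or still open speak of the compounds shown alone.

Three compounds of the shared core carry measurements in an assay on mitochondria from L6 cells (Rattus norvegicus) for activation, with a stated time of 90 min; a lower number here means that less compound is needed, a higher number that more compound is needed for the effect: compound 1 `Oc1nc2nonc2nc1Nc1ccc(OC(F)(F)F)cc1Cl` gives 1400 nM, compound 2 `CCCCOc1cccc(Nc2nc3nonc3nc2O)c1` gives 2300 nM, and compound 3 `CCCCOc1ccc(Nc2nc3nonc3nc2O)cc1` gives 3700 nM. Compound 3 stands at the upper end of the three numbers; its gap to compound 2 lies within the scatter, its gap to compound 1 beyond it. Compound 4 `Oc1nc2nonc2nc1Nc1ccc(OCC(F)(F)F)cc1` is not yet measured. It differs from compound 3 in one place: trifluoromethyl in place of propyl on a saturated chain carbon bound to an oxygen on an aromatic ring. Within the data shown here, no step between measured compounds tracks this change, so the direction rests only on compound 1 and its value of 1400 nM. The step is expected to be small, a 1.5-fold lower number from compound 3 to compound 4 (0.17 log units; within the scatter), toward a lower number. Compound 4 is estimated at 2500 nM, within 1000 nM to 6000 nM.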

Compound 4, half-maximal effective concentration: 42300 nM
Estimate against measurement, compound 4: 17-fold (1.23 log units) below; the whole stated range lies below it.
By their numbers in this assay, from the lowest: compounds 1, 2 and 3 (each within the scatter of the next, the first and the last beyond it); then compound 4.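

In this assay, among these compounds, this place on the shared core proves sensitive, which the earlier compounds, with no step among them, could not show: trifluoromethyl in place of propyl gives an 11-fold higher number from compound 3 to compound 4 (1.06 log units; beyond the scatter) as a large step. Butoxy and 2,2,2-trifluoroethoxy are therefore not interchangeable on this oxygen. Nothing measured here bears on the origin of this step. Still open, from the compounds shown here alone, is whether the step follows the fluorine atoms or the shorter chain. An unfluorinated ethoxy group, or a 4,4,4-trifluorobutoxy chain, would separate the two.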